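Swapping a Cyclobutyl for a Fluoropiperidine Ring

A few compounds are considered here, and "the series" means these few. Any claim that something is new, unique, unknown or untested is made for them only; others in the source may bear on it.

Of the compounds shown here, three built on a shared core have been tested in an assay on HEK293 cells for negative allosteric modulation of metabotropic glutamate receptor 5 (Homo sapiens), read by FLIPR, with a stated time of 1 h; a higher number here means a weaker inhibitor, a lower number a stronger inhibitor. Compound 1 `CN1CCc2nc(C#Cc3cccc(F)c3)sc2C1` carries a methyl on the amine nitrogen in its ring; in this assay compound 1 gives > 10000 nM, which is a limit of the assay rather than a number. Compound 2 `Fc1cccc(C#Cc2nc3c(s2)CN(C2CCC2)CC3)c1` carries a cyclobutyl at that nitrogen, and in this assay compound 2 gives 200 nM. The step of an at least 50-fold lower number from compound 1 to compound 2 (1.69 log units; beyond the scatter) is the only measured step among these compounds. Compound 3 `O=C(C1CCC1)N1CCc2nc(C#Cc3ccccc3)sc2C1` carries a cyclobutyl on a carbonyl carbon joined to the ring nitrogen, and in this assay compound 3 gives 370 nM. Compound 3 and compound 2 lie within the usual scatter of each other, and since compound 1 offers only a limit, no ranking of compound 3 can be drawn from these numbers.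

Compound 4 `O=C(N1CCC(F)CC1)N1CCc2nc(C#Cc3ccccc3)sc2C1` has not yet been measured. It differs from compound 3 in one place: 4-fluoropiperidin-1-yl in place of cyclobutyl on a carbonyl carbon. For the measured compounds named here, no measured step touches the group on the carbonyl carbon; the single measured step sits at the amine nitrogen and gives no direct guidance here. With nothing to lean on, the expected change is one no larger than the scatter, and the estimated step is a 1.1-fold higher number from compound 3 to compound 4 (0.03 log units; within the scatter). Compound 4 is therefore estimated at 400 nM, within a range from 130 nM to 1500 nM.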

Compound 4, half-maximal inhibitory concentration: > 10000 nM
Compound 4: only a limit was reported; the forecaster's own chance of this, stated with the estimate: 10%; at least 25-fold (1.39 log units) between middle value and limit.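

For the compounds shown here, at the carbonyl carbon, the group is not a free choice in this assay: 4-fluoropiperidin-1-yl in place of cyclobutyl gives an at least 27-fold higher number from compound 3 to compound 4 (1.43 log units; beyond the scatter), the first measured step at this position and a large one. Compound 4 gives > 10000 nM, which is a limit of the assay and not a number, so this step fixes only a minimum size for the change and not its true size. Compound 4 therefore stands with compound 1, and neither can be ranked against the other: the limit of > 10000 nM in this assay, at which 2 of the 4 values shown sit.

The entering group differs from cyclobutyl in more than one way, with a six-membered ring, a ring nitrogen and a fluorine all arriving together, and the compounds shown cannot say which of these goes with the step. A plain piperidin-1-yl on the same carbonyl carbon would separate the fluorine from the ring, while a cyclopentyl or a short open chain such as isopropyl would show how much change this position accepts before the number climbs to the limit.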